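Shortening a Benzyloxy to Methoxy in a Cytotoxicity Assay

This account rests on a few compounds, and the source may have more. Where it says the series, first, only, none or still open, it means among the compounds named here.

Compound 1 `CCOC(=O)CCCCCOc1cccc(CN(C(=O)c2ccc(-c3ccco3)cc2)C(C)C)c1`: > 26000 nM
Compound 2 `CCOC(=O)CCCCCOc1cccc(CN(C(=O)c2ccc(-c3cccc(OCc4ccccc4)c3)cc2)C(C)C)c1`: > 26000 nM

In an ADME assay on HEK293 cells (Homo sapiens) for cytotoxicity, read by CellTiter-Glo and resazurin assay, with a stated time of 72 h (a higher number here means that more compound is needed for the effect, a lower number that less compound is needed), compound 1 shows only a limit, > 26000 nM. Compound 2 likewise shows only a limit in this assay, > 26000 nM. Both values rest at the limit of > 26000 nM in this assay, at which 2 of the 2 values shown sit, so compound 2 stands at the limit rather than at a measured number.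

Compound 3 `CCOC(=O)CCCCCOc1cccc(CN(C(=O)c2ccc(-c3cccc(OC)c3)cc2)C(C)C)c1` differs from compound 2 by hydrogen in place of phenyl on a saturated chain carbon bound to an oxygen on an aromatic ring. No measured step of this kind exists among these compounds. In this assay the expected change from compound 2 to compound 3 is none beyond the scatter, a step that the limit leaves unreadable from compound 2 to compound 3. Compound 3 is therefore estimated at 40000 nM, within 15000 nM to 120000 nM, most likely reported again only as a limit.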

Compound 3, half-maximal effective concentration: > 21000 nM
Compound 3 gave a limit, no number; the forecaster's own chance of this, stated with the estimate: 85%; the middle value lies beyond the limit too.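

Among these compounds, compound 1, compound 2 and compound 3 each give only a limit in this assay, so no step among them can be read. From the compounds shown here alone, how far benzyloxy to methoxy shifts the half-maximal effective concentration stays open.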